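The compounds below may be only part of what the source reports. "The series", "measured", "known", "first", "only" and "open" are said of these compounds alone.

Measured in an ADME assay on microsomes from liver (Mus musculus) for metabolic stability; a lower number here means slower removal, a higher number faster removal of the compound:

- Compound 1 `Oc1c(-c2nc(C(O)c3ccccc3)n[nH]2)ncc2cccnc12`: 1.9 mL.min-1.g-1
- Compound 2 `Cc1n[nH]c(-c2ncc3cccnc3c2O)n1`: 3.3 mL.min-1.g-1
- Compound 3 `O=C1CCCN1Cc1n[nH]c(-c2ncc3cccnc3c2O)n1`: < 0.5 mL.min-1.g-1, a limit of the assay and not a number

Compound 2 stands level with compound 1, since the gap is a 1.7-fold higher number from compound 1 to compound 2 (0.24 log units; within the scatter). Compound 3 holds the only limit among the three results, (the limit of < 0.5 mL.min-1.g-1 in this assay, at which 1 of the 3 values shown sits).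

Compound 4 `Cc1n[nH]c(-c2ncc3c(N(C)C)ccnc3c2O)n1` carries dimethylamino in place of hydrogen on an aromatic carbon, opposite the ring nitrogen: dimethylamino in place of hydrogen on an aromatic carbon. Going by the values given here, no measured step touches that carbon, so the only guides come from changes elsewhere on the molecule. The step to compound 1 stayed within the scatter, while an at least 6.6-fold lower number from compound 2 to compound 3 (0.81 log units; beyond the scatter) went beyond it. These two steps give no shared direction, and neither can be carried over directly to the new place. A step beyond the scatter is therefore not expected in this assay, and the estimate is a 1.2-fold higher number from compound 2 to compound 4 (0.08 log units; within the scatter). For compound 4 the expected value is 4 mL.min-1.g-1, with an estimated range from 1.3 mL.min-1.g-1 to 12 mL.min-1.g-1.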

Compound 4, intrinsic clearance in microsomes: 14 mL.min-1.g-1
Compound 4: middle estimate off by 3.5-fold (0.54 log units), on the low side; the measured number lies above the stated range.
By their numbers in this assay, from the lowest: compounds 1 and 2 (each within the scatter of the next); then compound 4. At a limit, below all of these: compound 3.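

In this assay, going by these compounds alone, no earlier step touched the aromatic carbon opposite the ring nitrogen, and putting dimethylamino there in place of hydrogen gives a 4.2-fold higher number from compound 2 to compound 4 (0.63 log units; beyond the scatter). So this position is not silent: a change here moves the number beyond the scatter, and it does so towards faster removal, whereas the earlier step beyond the scatter, at a different place on the molecule, led from compound 2 to a lower result in compound 3. Nothing shown gives a measured reason for this rise.

One group cannot tell whether the rise belongs to dimethylamino itself or to any group on this carbon; methylamino, methoxy or a carboxylic acid there would help separate the two readings. On these data alone, it also stays open whether the 2-oxopyrrolidin-1-yl group of compound 3 would offset this rise if both changes sat on one molecule.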